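The source may hold more compounds than are shown below. What is called first, only, known or untested is meant among the compounds shown, and "the series" means these compounds.

Measured so far in a physicochemical assay for lipophilicity, read by HPLC, measured as octanol-water partition, at pH 7.2 (on this read-out higher numbers stand for higher lipophilicity and lower numbers for lower lipophilicity), for the series:
compound 1 `O=C(Nc1ccnc(C(F)(F)F)c1)Nc1ccnc(C(F)(F)F)c1` reads 3 as measured
compound 2 `O=C(Nc1ccnc(C(F)(F)F)c1)Nc1ccc(F)c(C(F)(F)F)c1` reads 3.8 as measured

Of these two values, compound 2 stands highest, and compound 1 lies lower by a gap beyond the scatter. Next in line, still unmeasured, is compound 3 `O=C(Nc1ccncc1)Nc1ccc(F)c(C(F)(F)F)c1` with hydrogen in place of trifluoromethyl on an aromatic carbon, next to the ring nitrogen. The counted difference is hydrogen in place of trifluoromethyl on an aromatic carbon in full.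

Within the data shown here, no measured pair shows this change on its own. The expectation in this assay therefore rests on the structural change alone, with compound 2 at 3.8 as the starting point. Estimated at a number 1.00 log units lower from compound 2 to compound 3 (beyond the scatter) here, the step is expected to go downward and to lie beyond the scatter. For compound 3 the expected value is 2.8 within an estimated range of 2.2 to 3.3 for now.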

Compound 3, distribution coefficient: 3.2
Compound 3: the middle estimate sits 0.40 log units below what was measured; the range from low to high includes it.
By their numbers in this assay, from the lowest: compounds 1 and 3 (each within the scatter of the next); then compound 2.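

In this assay, among these compounds, this is the first single-change reading at this position: hydrogen in place of trifluoromethyl on an aromatic carbon, next to the ring nitrogen, gives a number 0.60 log units lower from compound 2 to compound 3 (beyond the scatter) and counts as a modest step. Compounds 1 and 2 both carry trifluoromethyl at this carbon, so neither could show what this exchange does to the read-out on its own. No supporting data bear on the size of this step, which stands here as a bare measurement from one matched pair.

Other groups at this carbon, such as a methyl group, a chlorine atom, an amine or a methoxy group, remain open, so the step cannot yet be placed in any trend. On these data alone, whether the same exchange gives a similar step with a different group pattern on the other ring also remains open.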